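The source may hold more compounds than are shown below. What is called first, only, known or untested is meant among the compounds shown, and "the series" means these compounds.

Measured in a functional assay on Bel7402/5-FU cells (Homo sapiens) for antiproliferative activity, read by MTT assay, with a stated time of 72 h; a higher number here means a weaker inhibitor, a lower number a stronger inhibitor:
- Compound 1 `C=C1C(=O)O[C@H]2[C@H]1CC/C(Cn1cc(Cn3cc(F)c(=O)[nH]c3=O)nn1)=C\CC[C@@]1(C)O[C@@H]21`: > 20000 nM (a limit)
- Compound 2 `C=C1C(=O)O[C@H]2[C@H]1CC/C(COC(=O)CCC(=O)N1CCN(C(=O)Cn3cc(F)c(=O)[nH]c3=O)CC1)=C\CC[C@@]1(C)O[C@@H]21`: > 20000 nM (a limit)
- Compound 3 `C=C1C(=O)O[C@H]2[C@H]1CC/C(COC(=O)Cn1cc(F)c(=O)n(Cc3ccc(Br)cc3)c1=O)=C\CC[C@@]1(C)O[C@@H]21`: 3240 nM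

Compound 1 gives > 20000 nM, which is a limit of the assay and not a number. The same holds for compound 2 at > 20000 nM. Among the measured compounds shown here, compound 3, at 3240 nM, therefore carries the only actual number in the set, and it is the reference point for what follows.

Compound 4 `C=C1C(=O)O[C@H]2[C@H]1CC/C(COC(=O)Cn1cc(F)c(=O)n(Cc3ccc(F)c(F)c3)c1=O)=C\CC[C@@]1(C)O[C@@H]21` has not yet been measured. It keeps everything in compound 3 except one group: 3,4-difluorophenyl in place of 4-bromophenyl on a saturated chain carbon bound to an aromatic nitrogen. In words, 3,4-difluorophenyl takes the place of 4-bromophenyl on a saturated chain carbon bound to an aromatic nitrogen, so 4-bromobenzyl becomes 3,4-difluorobenzyl.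

For the measured compounds named here, no pair of measured compounds differs in one place, so the data give no direct size for such a change in this assay. A modest shift towards weaker inhibition is expected, anchored on compound 3 at 3240 nM. The expected change is a 1.5-fold higher number from compound 3 to compound 4 (0.19 log units; within the scatter). For compound 4 the estimated value is 5000 nM, with an expected range from 1800 nM to 16000 nM.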

Compound 4, half-maximal inhibitory concentration: 4480 nM
Beside the measured number, compound 4's estimate is 1.1-fold (0.05 log units) above it; low and high end bracket the measured number.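

In this assay, 4-bromobenzyl can be exchanged for 3,4-difluorobenzyl with a 1.4-fold higher number from compound 3 to compound 4 (0.14 log units; within the scatter). Among the compounds shown here, this gives the first measured step at this place, the saturated chain carbon bound to an aromatic nitrogen, and it shows that bromine is not needed there for a measured number of this size, as two fluorines on the phenyl ring serve within the scatter. The earlier compounds offered no such comparison, and two of them give only a limit: the limit of > 20000 nM in this assay, at which 2 of the 4 values shown sit.

Going by these compounds, both compounds in this pair carry a halogen-bearing phenyl ring, so what an unsubstituted phenyl, a pyridine or a carboxylic acid would do at this place stays open. Also open, on these data alone, is how a longer chain between the aromatic nitrogen and the phenyl ring would read in this assay.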